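Chalcone series: from compound 2 to compound 4

The source may hold more compounds than are shown below. What is called first, only, known or untested is meant among the compounds shown, and "the series" means these compounds.

Of the compounds shown here, three with a shared core have been measured in a functional assay on PC-3 cells (Homo sapiens), read by fluorescence and BrdU incorporation, with a stated time of 48 h, tested at 10 uM; a lower number here means a stronger effect, a higher number a weaker effect of the compound at the concentration tested. Compound 1 `COc1cc(O)c(C(=O)/C=C/c2ccc(F)cc2)c(OC)c1` gives 37%. Compound 2 `COc1cc(OC)c(C(=O)/C=C/c2ccc(Cl)cc2)c(OC)c1` gives 15%. Compound 3 `COc1cccc(/C=C/C(=O)c2c(O)cc(OC)cc2OC)c1` gives 39%. Among these three numbers compound 2 stands lowest, that is, it shows the strongest effect at the tested concentration; the gap to compound 1 and the gap to compound 3 both lie beyond the usual scatter. No pair of these compounds differs in only one place, so no single step can be read from them.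

Compound 4 `COc1cc(OC)c(C(=O)/C=C/c2ccccc2SC)c(OC)c1` has not yet been measured in this assay. It differs from compound 2 in one place: 2-(methylsulfanyl)phenyl in place of 4-chlorophenyl on a double-bonded chain carbon bound to a double-bonded chain carbon. Within the data shown here, nothing among the measured compounds shows how a change on this ring alters the read-out, so the direction of the step cannot be taken from the data. The expectation is that the step of a number 15 percentage points higher from compound 2 to compound 4 (beyond the scatter) will be a moderate rise, meaning a somewhat weaker effect than compound 2. For compound 4 the value in this assay is estimated at 30%, with a range from 10% to 55%.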

Compound 4, a percentage reported as activity, at one concentration (the size of the read-out at that concentration, not a potency): 30%
Compound 4: the middle estimate sits on the measured number at the digits printed; the measured number falls inside the stated range.
By their numbers in this assay, from the lowest: compound 2; then compounds 4, 1 and 3 (each within the scatter of the next).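

In this assay, among these compounds, putting 2-(methylsulfanyl)phenyl in place of 4-chlorophenyl gives a number 15 percentage points higher from compound 2 to compound 4 (beyond the scatter) and this is the first single change that can be read. It shows that the read-out responds to what this ring carries, even with the rest of the molecule held fixed, and here the change leads to a weaker effect. The step still bundles several differences, since the names show a different group at a different ring number and the entering group holds one hydrogen-bond acceptor where the leaving group holds none, and no data at hand say which of these matters or why the number rises.

The compounds shown leave open how this position behaves with a plain phenyl ring, which would help to show whether losing the chlorine or gaining the methylsulfanyl group accounts for the step. They also leave open what an amine or a carboxylic acid on this ring would do to the read-out, so a single step gives a direction for one swap and no trend across groups.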